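A Carbonyl Enters the Side Chain of Compound 1

A few compounds are considered here, and "the series" means these few. Any claim that something is new, unique, unknown or untested is made for them only; others in the source may bear on it.

Of the compounds shown here, three built on a shared core have been tested for their effect on liver-derived cells. In a functional assay on HepG2 cells (Homo sapiens) for cytotoxicity, read by crystal violet staining, with a stated time of 72 h (on this read-out lower numbers stand for stronger inhibition and higher numbers for weaker inhibition), compound 1 `COc1cc(/C=C/C(=O)/C=C(O)/C=C/c2ccc(O[C@H]3C=C(C)[C@@H](O)C[C@@H]3[C@@H](C)CCC=C(C)C)c(OC)c2)ccc1O` gives 25000 nM. Compound 2 `COc1cc(/C=C/C(=O)/C=C(O)/C=C/c2ccc(O[C@H]3C[C@H]([C@@H](C)CC(=O)C=C(C)C)C=C[C@@]3(C)O)c(OC)c2)ccc1O` gives 18300 nM, and compound 3 `COc1cc(/C=C/C(=O)/C=C(O)/C=C/c2cc(OC)c(O)c([C@H]3C=C(C)CC[C@@H]3[C@@H](C)CC(=O)C=C(C)C)c2)ccc1O` gives 50300 nM. Compound 1 thus stands second highest of the three numbers; its nearest neighbour is compound 2 and its furthest is compound 3, yet both gaps fall within the scatter of repeated measurements, so none of the three can be called more or less active than another. Among the measured compounds shown here, no step between measured compounds that differ in a single place is available.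

Compound 4 `COc1cc(/C=C/C(=O)/C=C(O)/C=C/c2ccc(O[C@H]3C=C(C)[C@@H](O)C[C@@H]3[C@@H](C)CC(=O)C=C(C)C)c(OC)c2)ccc1O` differs from compound 1 in one place: (2-methylprop-1-en-1-yl)carbonyl in place of 3-methylbut-2-en-1-yl on a saturated chain carbon, two bonds along the chain from a saturated ring carbon. The change places a carbonyl into the chain on a saturated chain carbon, two bonds along the chain from a saturated ring carbon.

Since all three measured compounds lie within the scatter of one another, these numbers offer no sign that a single change of this kind moves the read-out beyond the scatter. Compound 4 is therefore expected to give 25000 nM, within a range of 12000 nM to 50000 nM. The step this estimate means, no change at the digits printed from compound 1 to compound 4 (within the scatter), is expected to be none beyond the scatter.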

Compound 4, half-maximal inhibitory concentration: 15400 nM
The estimate for compound 4 lay 1.6-fold (0.21 log units) above the measured number; the range from low to high includes it.
By their numbers in this assay, from the lowest: compounds 4, 2, 1 and 3 (each within the scatter of the next, the first and the last beyond it).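

Among the compounds shown here, with this step, the position on the side chain can be read for the first time. In this assay, (2-methylprop-1-en-1-yl)carbonyl in place of 3-methylbut-2-en-1-yl on a saturated chain carbon, two bonds along the chain from a saturated ring carbon gives a 1.6-fold lower number from compound 1 to compound 4 (0.21 log units; within the scatter), so the two compounds cannot be told apart on this read-out. The exchange brings in a hydrogen-bond acceptor and a second double bond outside aromatic rings, and for this one pair that does not carry the number beyond the scatter; no measurement shown here offers an explanation of the result.

Going by these compounds, the step changes the carbonyl and the double bond together, so what each contributes alone remains open. Also open, on these data alone, is whether a different group at this place on the shared core, such as an amine, a carboxylic acid or a longer chain, would move the number beyond the scatter.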